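The source may report more compounds than this note shows. Statements on the series, on what has been measured and on what is new or still open speak of the compounds shown alone.

In a functional assay on MCF7 cells (Homo sapiens) for cytotoxicity, read by MTT assay, with a stated time of 48 h (on this read-out higher numbers stand for weaker inhibition and lower numbers for stronger inhibition), compound 1 `O=C(CSc1nnc(-c2ccncc2)o1)N/N=C/c1cccc(F)c1` gives 24900 nM, compound 2 `O=C(CSc1nnc(-c2ccncc2)o1)N/N=C/c1ccccc1O` gives 4750 nM and compound 3 `O=C(CSc1nnc(-c2ccncc2)o1)N/N=C/c1cc(Br)ccc1O` gives 7770 nM. Compound 3 belongs to the lower pair of these numbers: the measured steps are a 3.2-fold lower number from compound 1 to compound 3 (0.51 log units; beyond the scatter) and a 5.2-fold lower number from compound 1 to compound 2 (0.72 log units; beyond the scatter), while adding bromo gives a 1.6-fold higher number from compound 2 to compound 3 (0.21 log units; within the scatter). Compound 4 `O=C(CSc1nnc(-c2ccncc2)o1)N/N=C/c1ccc(Cl)cc1Cl` differs by 2,4-dichlorophenyl in place of 5-bromo-2-hydroxyphenyl on a carbon with a double bond to nitrogen. Among the measured compounds shown here, no measured step makes this exact change, but compound 4, like compound 1 at 24900 nM, has no hydroxy group. A modest rise in this assay is therefore expected, roughly reversing those two steps from compound 1. The expected change is a 2.1-fold higher number from compound 3 to compound 4 (0.31 log units; beyond the scatter). For compound 4 the estimate is 16000 nM, with an expected range of 6000 nM to 40000 nM.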

Compound 4, half-maximal inhibitory concentration: 27900 nM
Beside the measured number, compound 4's estimate is 1.7-fold (0.24 log units) below it; the range from low to high includes it.
By their numbers in this assay, from the lowest: compounds 2 and 3 (each within the scatter of the next); then compounds 1 and 4 (each within the scatter of the next).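

In this assay, 2,4-dichlorophenyl in place of 5-bromo-2-hydroxyphenyl raises the number (a 3.6-fold higher number from compound 3 to compound 4 (0.56 log units; beyond the scatter)), and in place of 2-hydroxyphenyl it does so too (a 5.9-fold higher number from compound 2 to compound 4 (0.77 log units; beyond the scatter)), so a second compound without the hydroxy group now stands beyond the scatter from both hydroxy compounds. The two groups without hydroxy stay level despite their different halogens (a 1.1-fold higher number from compound 1 to compound 4 (0.05 log units; within the scatter)). Nothing available explains these differences. Going by these compounds, whether a methoxy group or an amine on this aromatic ring would give numbers like those of compound 2 and compound 3 remains open.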